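This account rests on a few compounds, and the source may have more. Where it says the series, first, only, none or still open, it means among the compounds named here.

Measured so far: compound 1 `O=c1[nH]c(=O)n([C@@H]2O[C@H](COP(=O)(O)OP(=O)(O)OP(=O)(O)O)[C@@H](O)[C@H]2O)cc1Br`, 347 nM; compound 3 `O=c1[nH]c(=O)n([C@@H]2O[C@H](COP(=O)(O)OP(=O)(O)O)[C@@H](O)[C@H]2O)cc1Br`, 3670 nM; compound 2 `O=c1ccn([C@@H]2O[C@H](COP(=O)(O)OP(=O)(O)O)[C@@H](O)[C@H]2O)c(=S)[nH]1`, > 1000 nM.

In an in vitro functional assay on 1321-N1 cells for agonist activity at P2Y purinoceptor 2 (Homo sapiens) (a higher number here means that more compound is needed for the effect, a lower number that less compound is needed), compound 1 gives 347 nM. Compound 3 gives 3670 nM, a step of an 11-fold higher number from compound 1 to compound 3 (1.02 log units; beyond the scatter), the change being (a hydrogen atom in place of a group of 4 heavy atoms (3 oxygen, 1 phosphorus; no ring), on an oxygen). Compound 2 is reported only as a limit of this assay, > 1000 nM, not as a number (the limit of > 1000 nM in this assay, at which 1 of the 3 values shown sits). How the core of compound 2 differs from that of compound 1 is not broken down here.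

Compound 4 `O=c1ccn([C@@H]2O[C@H](COP(=O)(O)O)[C@@H](O)[C@H]2O)c(=S)[nH]1` has not yet been measured in this assay. It differs from compound 2 by the same change as that from compound 1 to compound 3: a hydrogen atom in place of a group of 4 heavy atoms (3 oxygen, 1 phosphorus; no ring), on an oxygen.

Given that compound 2 already sits at the limit > 1000 nM and that the same change gave the large step of an 11-fold higher number from compound 1 to compound 3 (1.02 log units; beyond the scatter), the step from compound 2 to compound 4 is expected to be a step that the limit leaves unreadable from compound 2 to compound 4. For compound 4 the estimated value in this assay is 20000 nM, expected to lie between 3000 nM and 100000 nM, most likely again reported only as a limit.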

Compound 4, half-maximal effective concentration: >= 100000 nM
Compound 4: no number, only a limit; the forecaster's own chance of this, stated with the estimate: 80%; at least 5.0-fold (0.69 log units) between middle value and limit.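

Within the data shown here, compound 2 and compound 4 are both reported in this assay only as limits, so no step between them can be read. The compounds shown leave open whether this change has as large an effect on the core of compound 2 as on that of compound 1.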